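A few compounds are considered here, and "the series" means these few. Any claim that something is new, unique, unknown or untested is made for them only; others in the source may bear on it.

Compound 1 `CCCCS(=O)(=O)NNC(=O)[C@@H](NC(=O)c1cccc(Cn2ccnc2)c1)[C@@H](C)CC`: > 100000 nM
Compound 2 `CC[C@H](C)[C@H](NC(=O)c1cccc(Cn2ccnc2)c1)C(=O)NC#N`: "not determined" (no result reported)

In an assay on HEK293 cells for displacement of a labelled ligand from Type-2 angiotensin II receptor (Homo sapiens) (on this read-out lower numbers stand for stronger inhibition and higher numbers for weaker inhibition), compound 1 gives > 100000 nM, which is a limit of the assay and not a number. For compound 2 no result was reported in this assay, so compound 2 stands on no number at all. For the measured compounds named here, the one value shown for the set, that of compound 1, is the limit of > 100000 nM in this assay, at which 1 of the 2 values shown sits. Compound 3 `CC[C@H](C)[C@H](NC(=O)c1cccc(Cn2ccnc2)c1)C(=O)NS(=O)(=O)c1ccccc1` differs from compound 2 by phenylsulfonyl in place of cyano on an amide-type nitrogen. Going by the values given here, no measured step frames this change, and with compound 2 unmeasured nothing anchors the direction or size of the expected shift. Compound 3 is estimated to give 20000 nM in this assay, with a range from 500 nM to 100000 nM.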

Compound 3, inhibition constant: 18000 nM
The estimate for compound 3 lay 1.1-fold (0.05 log units) above the measured number, and the stated range covers the measured number.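

With phenylsulfonyl in place of (butylsulfonyl)amino on the amide-type nitrogen, the set shows an at least 5.5-fold lower number from compound 1 to compound 3 (0.74 log units; beyond the scatter). For the compounds shown here, compound 3 thus gives the first actual number in this assay, showing that a change at this nitrogen can move the read-out. The true size of the step stays unknown, as compound 1 stands at a limit of the assay and not at a number: the limit of > 100000 nM in this assay, at which 1 of the 3 values shown sits.

The step from compound 2 to compound 3 cannot be read. As far as these compounds go, whether a carboxylic acid or an amine on this nitrogen would lower the number further remains open.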